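The source may report more compounds than this note shows. Statements on the series, on what has been measured and on what is new or still open speak of the compounds shown alone.

For the measured compounds named here, compound 1 `COc1ccc(CNCCCNS(=O)(=O)c2cc(C(F)(F)F)cc(C(F)(F)F)c2)cc1OC` gives 15000 nM in a functional assay on Capan-2 cells (Homo sapiens) for inhibition, read by MTT assay, with a stated time of 72 h (a lower number here means a stronger inhibitor of growth, a higher number a weaker inhibitor of growth), the highest of the three numbers measured so far. Compound 2 `O=S(=O)(NCCCNCc1cccc(Cl)c1)c1cc(C(F)(F)F)cc(C(F)(F)F)c1` gives 8000 nM, a change of a 1.9-fold lower number from compound 1 to compound 2 (0.27 log units; within the scatter). Compound 3 `O=S(=O)(NCCCNCC1COc2ccccc2O1)c1cc(C(F)(F)F)cc(C(F)(F)F)c1` gives 2500 nM, a change of a 6.0-fold lower number from compound 1 to compound 3 (0.78 log units; beyond the scatter); between these two, the number moves by a 3.2-fold lower number from compound 2 to compound 3 (0.51 log units; beyond the scatter). Compound 4 `COc1ccccc1CNCCCNS(=O)(=O)c1cc(C(F)(F)F)cc(C(F)(F)F)c1` has not yet been measured. It differs from compound 1 in one place: 2-methoxyphenyl in place of 3,4-dimethoxyphenyl on a saturated chain carbon bound to an amine nitrogen. Going by the values given here, the steps that bear on this are the two that likewise replace the 3,4-dimethoxyphenyl of compound 1 on a saturated chain carbon bound to an amine nitrogen, namely a 1.9-fold lower number from compound 1 to compound 2 (0.27 log units; within the scatter) and a 6.0-fold lower number from compound 1 to compound 3 (0.78 log units; beyond the scatter). Both replacements lowered the number, the first within the scatter, the second modestly beyond it. A small downward move is therefore expected, an expected step of a 1.5-fold lower number from compound 1 to compound 4 (0.18 log units; within the scatter). The estimate for compound 4 in this assay is 10000 nM, with a range from 4000 nM to 25000 nM.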

Compound 4, concentration for 50% growth inhibition: 6000 nM
Estimate against measurement, compound 4: 1.7-fold (0.22 log units) above, within the range that was stated.
By their numbers in this assay, from the lowest: compound 3; then compounds 4, 2 and 1 (each within the scatter of the next, the first and the last beyond it).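

In this assay, the 3,4-dimethoxybenzyl to 2-methoxybenzyl change gives (a 2.5-fold lower number from compound 1 to compound 4 (0.40 log units; beyond the scatter)). All three replacements of the 3,4-dimethoxyphenyl group at this place have now lowered the number, and this step lies beyond the scatter, although the replacement in compound 2 stayed within it. The 2-methoxyphenyl and 3-chlorophenyl groups cannot be told apart (see a 1.3-fold lower number from compound 2 to compound 4 (0.12 log units; within the scatter)), while the 2,3-dihydro-1,4-benzodioxin-2-yl group retains a modest lead over the 2-methoxyphenyl group (see a 2.4-fold higher number from compound 3 to compound 4 (0.38 log units; beyond the scatter)), and no supporting data explain these differences.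

The compounds shown leave open how a 2-ethoxyphenyl or pyridyl group would behave on the same saturated chain carbon. They also leave open whether a longer chain in the shared core would preserve this order.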